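The compounds below may be only part of what the source reports. "The series", "measured", "known", "first", "only" and "open" are said of these compounds alone.

Of the compounds shown here, two have been measured in an assay on HEK293 cells for antagonist activity at Toll-like receptor 9 (Homo sapiens), read by spectrophotometry; a lower number here means a stronger inhibitor, a higher number a weaker inhibitor. Compound 1, `CCN1CCN(CCCn2cnc3c(N4CCN(CC)CC4)ncnc32)CC1`, gives 1190 nM. Compound 2, `COc1ccc(CNc2nc(N3CCN(C4CCCC4)CC3)c3ncn(CCCN4CCCC4)c3n2)cc1`, gives 240 nM and stands as the lower of the two numbers; the gap to compound 1 lies beyond the scatter.

Compound 3, `CCN1CCN(c2nc(NCc3ccc(OC)cc3)nc3c2ncn3CCCN2CCCC2)CC1`, has not yet been measured. It differs from compound 2 in one place: ethyl in place of cyclopentyl on an amine nitrogen in a ring. The rest of compound 2, including the methoxybenzylamino group and the pyrrolidinylpropyl chain, is kept.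

Among the measured compounds shown here, no measured pair shows this change in isolation, so the size of the step cannot be read from the data. A small step toward a higher number, close to or just beyond the scatter, is expected for compound 3, as a 1.9-fold higher number from compound 2 to compound 3 (0.27 log units; within the scatter). The estimate for compound 3 in this assay is 450 nM, with a range from 150 nM to 1300 nM.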

Compound 3, half-maximal inhibitory concentration: 80 nM
For compound 3 the middle estimate is 5.6-fold (0.75 log units) above the measured one; the whole stated range lies above it.
By their numbers in this assay, from the lowest: compound 3; then compound 2; then compound 1.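

Going from 4-cyclopentylpiperazin-1-yl to 4-ethylpiperazin-1-yl gives a 3.0-fold lower number from compound 2 to compound 3 (0.48 log units; beyond the scatter) in this assay, the first reading of this position on its own. With the methoxybenzylamino group and the pyrrolidinylpropyl chain held fixed, the group on this amine nitrogen therefore moves the number beyond the scatter, and the five-membered carbon ring of cyclopentyl is not required for the inhibition seen here, since the open ethyl group gives the lower number. No supporting data bear on why this step occurs.

Going by these compounds, a single step sets no trend, so it remains open whether methyl, isopropyl or cyclohexyl on the same nitrogen would fall nearer to ethyl or to cyclopentyl. On these data alone, it is also open whether the step would hold with another group in place of the methoxybenzylamino group.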